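A 3-nitrophenyl swap in a tightly grouped series

The source may report more compounds than this note shows. Statements on the series, on what has been measured and on what is new or still open speak of the compounds shown alone.

Compound 1 `CCCCCCCCCCCCCCNC(=O)[C@H](CO)/N=C/c1ccc(OC)cc1` gives 28100 nM
Compound 2 `CCCCCCCCCCCCCCNC(=O)[C@H](CO)/N=C/c1ccccc1O` gives 19000 nM
Compound 3 `CCCCCCCCCCCCCCNC(=O)[C@H](CO)/N=C/c1ccc(Cl)cc1` gives 27500 nM

In a functional assay on cells (Homo sapiens) for cytotoxicity, read by MTT assay, with a stated time of 24 h (a lower number here means a stronger inhibitor, a higher number a weaker inhibitor), compound 1 stands at 28100 nM and within the scatter of both other measured compounds, so it holds no separate place among them. Compound 4 `CCCCCCCCCCCCCCNC(=O)[C@H](CO)/N=C/c1cccc([N+](=O)[O-])c1` has not yet been measured. It differs from compound 1 by 3-nitrophenyl in place of 4-methoxyphenyl on a carbon with a double bond to nitrogen. Two measured steps alter that group: the first is a 1.5-fold lower number from compound 1 to compound 2 (0.17 log units; within the scatter) and the second is a 1.0-fold lower number from compound 1 to compound 3 (0.01 log units; within the scatter) and both stay within the scatter. Among the measured compounds shown here, no measured compound carries 3-nitrophenyl, so no direction is favoured in this assay and no step beyond the scatter is expected. The expected step is a 1.2-fold lower number from compound 1 to compound 4 (0.07 log units; within the scatter) and remains within the scatter. Compound 4 is estimated at 24000 nM (expected range 12000 nM to 45000 nM).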

Compound 4, half-maximal inhibitory concentration: 104000 nM
The estimate for compound 4 lay 4.3-fold (0.64 log units) below the measured number; the whole stated range lies below it.
By their numbers in this assay, from the lowest: compounds 2, 3 and 1 (each within the scatter of the next); then compound 4.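

In this assay the group on the carbon with a double bond to nitrogen proved able to move the number: 3-nitrophenyl gives a 3.7-fold higher number from compound 1 to compound 4 (0.57 log units; beyond the scatter) and a 3.8-fold higher number from compound 3 to compound 4 (0.58 log units; beyond the scatter) and a 5.5-fold higher number from compound 2 to compound 4 (0.74 log units; beyond the scatter) while the three earlier groups stayed within the scatter of one another. Among these four compounds, only 3-nitrophenyl weakens the inhibitor beyond the scatter. Nothing available explains this shift. Going by these compounds, whether the nitro group itself carries the loss remains open, and so does whether an amine or a carboxylic acid in its place on the phenyl ring would behave alike.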